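From isobutyl to butyl on a sulfonamide nitrogen

The source may hold more compounds than are shown below. What is called first, only, known or untested is meant among the compounds shown, and "the series" means these compounds.

Measured so far in a functional assay on K562 cells (Homo sapiens) for antiproliferative activity, read by CCK-8 assay, with a stated time of 72 h; on this read-out higher numbers stand for weaker inhibition of growth and lower numbers for stronger inhibition of growth:
- Compound 1 `CCC1C(=O)N(C)c2cnc(Nc3ccc(S(=O)(=O)NCC(C)C)cc3)nc2N1c1ccn(C)n1`: 7300 nM
- Compound 2 `CCCCNS(=O)(=O)c1ccc(Nc2ncc3c(n2)N(C2CCCC2)[C@H](CC)C(=O)N3C)cc1`: 412 nM

Of these two numbers, compound 1 has the higher, at 7300 nM, which means the weaker inhibition of growth. Compound 2, at 412 nM, has the lower number, and the gap between the two lies beyond the scatter.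

Compound 3 `CCCCNS(=O)(=O)c1ccc(Nc2ncc3c(n2)N(c2ccn(C)n2)C(CC)C(=O)N3C)cc1` has not yet been measured. It differs from compound 1 in a single place: propyl in place of isopropyl on a saturated chain carbon bound to a sulfonamide nitrogen. This puts propyl in place of isopropyl on a saturated chain carbon bound to a sulfonamide nitrogen. Cut one bond further out, the same difference reads isobutyl to butyl.

Within the data shown here, no pair of measured compounds shows this change alone, so the data give no direct size for it. The expectation therefore starts from compound 1 at 7300 nM. In this assay, no change beyond the scatter is expected in either direction, and the estimated 1.3-fold lower number from compound 1 to compound 3 (0.12 log units; within the scatter) is small. For compound 3 the expected value is 5500 nM, with an estimated range from 2000 nM to 13000 nM.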

Compound 3, concentration for 50% growth inhibition: 4240 nM
Beside the measured number, compound 3's estimate is 1.3-fold (0.11 log units) above it; low and high end bracket the measured number.
By their numbers in this assay, from the lowest: compound 2; then compounds 3 and 1 (each within the scatter of the next).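

In this assay, among these compounds, the exchange of isobutyl for butyl gives a 1.7-fold lower number from compound 1 to compound 3 (0.24 log units; within the scatter), and this is the first direct size for the change, which no earlier pair could supply. On a saturated chain carbon bound to a sulfonamide nitrogen, propyl in place of isopropyl therefore leaves the number within the usual scatter, so this read-out does not tell the two chains apart in this pair. Among the compounds shown here, this is a single pair on the core of compound 1, so it shows only that this one swap of chains with the same heavy atoms has no effect that can be told from the scatter. Nothing available here bears on why the two chains read alike.

The compounds shown leave open whether a longer chain such as hexyl, a ring such as cyclohexyl, or a chain carrying an amine or a carboxylic acid in place of butyl would move the number beyond the scatter. They also leave open whether propyl in place of isopropyl would read the same way on a core carrying other groups.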